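The source may report more compounds than this note shows. Statements on the series, on what has been measured and on what is new or still open speak of the compounds shown alone.

Compound 1 `CCCCCCCCCCCCNC(=O)[C@@H](NC(=O)c1cc2ccccc2n1C)[C@@H](C)O` in a functional assay on A-431 cells (Homo sapiens) for cytotoxicity, read by MTT assay, with a stated time of 48 h (a higher number here means a weaker inhibitor, a lower number a stronger inhibitor), gives 169000 nM. Compound 2 `CCCCCCCCCCCCNC(=O)[C@@H](NC(=O)/C=C/c1ccccc1)[C@@H](C)O` differs from it by 2-phenylethenyl in place of 1-methyl-1H-indol-2-yl on a carbonyl carbon. In this assay compound 2 reaches only a limit of the assay, > 200000 nM. That change made an at least 1.1-fold higher number from compound 1 to compound 2 (0.07 log units; that floor lies within the scatter). Compound 3 `CCCCCCCCCCCCCCCCCCNC(=O)[C@@H](NC(=O)c1cc2ccccc2n1C)[C@@H](C)O` differs from compound 1 by hexyl in place of hydrogen on a saturated chain carbon, ten or more bonds along the chain from an amide-type nitrogen, and in this assay compound 3 gives 61000 nM, a step of a 2.8-fold lower number from compound 1 to compound 3 (0.44 log units; beyond the scatter). Compound 4 `CCCCCCCCCCCCCCCCCCNC(=O)[C@@H](NC(=O)/C=C/c1ccccc1)[C@@H](C)O` stands to compound 3 as compound 2 stands to compound 1: the change is 2-phenylethenyl in place of 1-methyl-1H-indol-2-yl on a carbonyl carbon, the same change at the same place. The step from compound 3 to compound 4 is expected to be a 2.0-fold higher number from compound 3 to compound 4 (0.29 log units; within the scatter), set beside the earlier at least 1.1-fold higher number from compound 1 to compound 2 (0.07 log units; that floor lies within the scatter), which ended at the limit of > 200000 nM in this assay, at which 1 of the 3 values shown sits, and so may be larger than its floor. Compound 4 is therefore estimated at 120000 nM, with a range from 60000 nM to 200000 nM.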

Compound 4, half-maximal inhibitory concentration: 177000 nM
Estimate against measurement, compound 4: 1.5-fold (0.17 log units) below; low and high end bracket the measured number.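

In this assay, 2-phenylethenyl in place of 1-methyl-1H-indol-2-yl on a carbonyl carbon gives a 2.9-fold higher number from compound 3 to compound 4 (0.46 log units; beyond the scatter), so on this core the change can be read as a real step. It does not show whether the step carries over from one core to the other with the same size, as compound 2 stands at a limit of the assay: the same change on two cores in this assay, an at least 1.1-fold higher number (0.07 log units; that floor lies within the scatter) from compound 1 to compound 2 and a 2.9-fold higher number (0.46 log units; beyond the scatter) from compound 3 to compound 4; the limit leaves it open whether they differ. That limit also leaves the chain step, an at least 1.1-fold lower number from compound 2 to compound 4 (0.05 log units; that floor lies within the scatter), without a readable size, so it cannot be set firmly against the earlier one: the same change on two cores in this assay, a 2.8-fold lower number (0.44 log units; beyond the scatter) from compound 1 to compound 3 and an at least 1.1-fold lower number (0.05 log units; that floor lies within the scatter) from compound 2 to compound 4; the limit leaves it open whether they differ. The compounds shown leave open how an amine or a carboxylic acid in place of 2-phenylethenyl would read in this assay. They also leave open whether a shorter chain would follow the same steps.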